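This account rests on a few compounds, and the source may have more. Where it says the series, first, only, none or still open, it means among the compounds named here.

Measured so far:
- compound 1 `O=c1cc(-c2ccccc2)oc2c(OCCCCN3CCCC3)c(OCc3ccccc3)cc(O)c12` — 1890 nM
- compound 2 `Cc1ccc(COc2cc(O)c3c(=O)cc(-c4ccccc4)oc3c2OCCCCN2CCN(C)CC2)cc1` — 2220 nM

Both numbers come from a functional assay on MCF7 cells (Homo sapiens) for cytotoxicity, read by MTT assay, with a stated time of 72 h; a lower number here means a stronger inhibitor, a higher number a weaker inhibitor. Compound 2 gives the highest of the two numbers, yet compound 1 sits within the usual scatter of it, so the two values cannot be told apart on this evidence.

Compound 3 `CN1CCN(CCCCOc2c(OCc3cccs3)cc(O)c3c(=O)cc(-c4ccccc4)oc23)CC1` has not been measured. It differs from compound 2 in one place: thiophen-2-yl in place of 4-methylphenyl on a saturated chain carbon bound to an oxygen on an aromatic ring. Among the measured compounds shown here, no measured pair shows this particular exchange, so there is no known step to lean on. In this assay the expectation is therefore a small step at most, leaning toward a somewhat higher number, or no step beyond the scatter at all. Compound 3 is estimated at 2600 nM, with a range from 1000 nM to 6500 nM. The step this estimate implies is a 1.2-fold higher number from compound 2 to compound 3 (0.07 log units; within the scatter).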

Compound 3, half-maximal inhibitory concentration: 3180 nM
Estimate against measurement, compound 3: 1.2-fold (0.09 log units) below, and the stated range covers the measured number.
By their numbers in this assay, from the lowest: compounds 1, 2 and 3 (each within the scatter of the next).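

In this assay, thiophen-2-yl in place of 4-methylphenyl on a saturated chain carbon bound to an oxygen on an aromatic ring gives a 1.4-fold higher number from compound 2 to compound 3 (0.16 log units; within the scatter), so the two values cannot be told apart. At this position, a five-membered aromatic ring with one hetero atom therefore reads the same in this assay as a six-membered aromatic ring of carbon only, even with two fewer heavy atoms and one more hydrogen-bond acceptor. Nothing given here explains this result.

From the compounds shown here alone, whether any group at this place can move the number beyond the scatter remains open. A pyridine ring, a cyclohexyl ring or a phenyl ring carrying a carboxylic acid could each test this, and so could a longer chain between the oxygen and the ring.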